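Swapping bromo for chloro on a urea-hydrazone anticonvulsant

This account rests on a few compounds, and the source may have more. Where it says the series, first, only, none or still open, it means among the compounds named here.

Compound 1, `O=C(N/N=C/c1ccc(Br)cc1)Nc1cccc2ccccc12`, was tested in a functional assay on the whole organism (strain Swiss albino) with Mus musculus as the target, in the maximal electroshock model, with a stated time of 4 h; a lower number here means that less compound is needed, a higher number that more compound is needed for the effect. In this assay compound 1 gives 300 mg/kg. The only measured neighbour, compound 2, `C/C(=N\NC(=O)Nc1cccc2ccccc12)c1ccc(Cl)cc1Cl`, shares the same core and gives 300 mg/kg in this assay, so compound 1 stands level with compound 2 at the digits shown, the two values lying within the usual scatter of each other. For the measured compounds named here, no two measured compounds differ in a single place, so no measured step is available.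

The next compound, compound 3, `O=C(N/N=C/c1ccc(Cl)cc1)Nc1cccc2ccccc12`, differs from compound 1 in one place: chloro in place of bromo on an aromatic carbon. Both groups count as one heavy atom, bring no ring, and add no hydrogen-bond donors or acceptors, so the change is a small one at the edge of the molecule.

Going by the values given here, with no measured step to lean on, the expectation is a step from compound 1 to compound 3 of no change at the digits printed from compound 1 to compound 3 (within the scatter), that is, no change beyond the scatter. Compound 3 is therefore estimated to give 300 mg/kg in this assay, with a range from 150 mg/kg to 600 mg/kg.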

Compound 3, minimum effective dose: 300 mg/kg
Compound 3: middle estimate and measured number agree at the digits printed; low and high end bracket the measured number.
By their numbers in this assay, from the lowest: compounds 1, 2 and 3 (each within the scatter of the next).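

In this assay, for the compounds shown here, putting chloro in place of bromo on the aromatic carbon para to a large group gives no change at the digits printed from compound 1 to compound 3 (within the scatter), and this is the first reading of a change made in one place only. Compound 1 and compound 2 differ in more than one place, so their printed values could say nothing about this position alone, whereas compound 1 and compound 3 isolate it, showing that the exchange of these two groups leaves the minimum effective dose where it was. Nothing measured here explains why the two groups read alike.

The compounds shown leave open whether this position accepts only bromo and chloro or would read the same with a group of a different kind, such as an amine, a carboxylic acid or a longer chain. They also leave open whether the same exchange of bromo for chloro would read the same way on a different aromatic position of the shared core.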